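Trading a Long Chain for a Ring

The compounds below may be only part of what the source reports. "The series", "measured", "known", "first", "only" and "open" are said of these compounds alone.

In a functional assay on T98G cells (Homo sapiens) for cytotoxicity, read by MTT assay, with a stated time of 48 h (on this read-out lower numbers stand for stronger inhibition and higher numbers for weaker inhibition), compound 1 `CCOC(=O)C[n+]1cccc2cc(O)ccc21` reaches only a limit, > 200000 nM, so it gives no actual number. Two related compounds do give numbers. Compound 2 `C[n+]1cccc(OP(=O)([O-])OC[C@H]2O[C@@H](n3cc(F)c(=O)[nH]c3=O)C[C@@H]2OC(=O)c2ccccc2)c1` gives 3480 nM, and compound 3 `CCCCCCCCCC[n+]1cccc(OP(=O)([O-])OC[C@H]2O[C@@H](n3cc(F)c(=O)[nH]c3=O)C[C@@H]2OC(=O)c2ccccc2)c1` gives 400 nM, the lower of the two and so the stronger result.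

For the measured compounds named here, only one measured step bears on what comes next. Placing nonyl in place of hydrogen on a saturated chain carbon bound to an aromatic nitrogen gave an 8.7-fold lower number from compound 2 to compound 3 (0.94 log units; beyond the scatter). Compound 4 `O=C(O[C@H]1C[C@H](n2cc(F)c(=O)[nH]c2=O)O[C@@H]1COP(=O)([O-])Oc1ccc[n+](Cc2ccccc2)c1)c1ccccc1` is altered at that same place: phenyl in place of nonyl on a saturated chain carbon bound to an aromatic nitrogen. Phenyl stands in place of nonyl, which turns decyl into benzyl.

A single step is a thin guide, and no ring at this place has been measured yet. Part of the gain seen in an 8.7-fold lower number from compound 2 to compound 3 (0.94 log units; beyond the scatter) is expected to be lost in this assay, though not all of it. The expected change is a 3.3-fold higher number from compound 3 to compound 4 (0.51 log units; beyond the scatter). For compound 4 the estimated value is 1300 nM, with an expected range of 450 nM to 3800 nM.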

Compound 4, half-maximal inhibitory concentration: 2600 nM
Beside the measured number, compound 4's estimate is 2.0-fold (0.30 log units) below it; the range from low to high includes it.
By their numbers in this assay, from the lowest: compound 3; then compounds 4 and 2 (each within the scatter of the next). At a limit, above all of these: compound 1.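

In this assay, a ring at this place does not do what the long chain did: a 6.5-fold higher number from compound 3 to compound 4 (0.81 log units; beyond the scatter) shows that exchanging nonyl for phenyl gives up much of the earlier gain. Phenyl in place of hydrogen at the same carbon gives a 1.3-fold lower number from compound 2 to compound 4 (0.13 log units; within the scatter), so benzyl and the small group of the earlier compound cannot be told apart here. Adding carbon at this place is therefore not enough on its own, since decyl separates from the small group and benzyl does not, and nothing measured here explains this difference.

A hexyl chain could show how much length is needed, and a dodecyl chain whether still more length lowers the number further. On these data alone, whether benzyl carrying an amine or a carboxylic acid would behave like plain benzyl also remains open.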